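The source may hold more compounds than are shown below. What is called first, only, known or untested is meant among the compounds shown, and "the series" means these compounds.

Compound 1 `CCCCCCCCCCCCNC[C@@H]1OC[C@H](N)[C@@H]1O` and compound 2 `CCCCCCCCCCCNC[C@@H]1OC[C@H](N)[C@@H]1O` share one core and differ only in the length of the saturated chain on the amine nitrogen. In a functional assay on MCF7 cells (Homo sapiens) for antiproliferative activity, read by MTT assay, with a stated time of 72 h (a higher number here means a weaker inhibitor, a lower number a stronger inhibitor), compound 1 gives 1800 nM, and compound 2 gives 6770 nM. Among the compounds with values here, the one step measured so far, a 3.8-fold higher number from compound 1 to compound 2 (0.58 log units; beyond the scatter), already points in one direction: the shorter chain went with the higher number. Within the data shown here, compound 2 thus stands at the highest of the two numbers in this assay, with compound 1 as its only neighbour.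

Compound 3 `CCCCCCCCCNC[C@@H]1OC[C@H](N)[C@@H]1O` takes the same chain further down: hydrogen in place of ethyl on a saturated chain carbon, nine bonds along the chain from an amine nitrogen. Since the step from compound 1 to compound 2 was modest but beyond the scatter, and this change removes two chain carbons rather than one, a larger rise in the number is expected. Compound 3 is therefore estimated at 35000 nM, within 12000 nM to 100000 nM, a step of a 5.2-fold higher number from compound 2 to compound 3 (0.71 log units; beyond the scatter).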

Compound 3, half-maximal inhibitory concentration: 12500 nM
Beside the measured number, compound 3's estimate is 2.8-fold (0.45 log units) above it, within the range that was stated.
By their numbers in this assay, from the lowest: compound 1; then compounds 2 and 3 (each within the scatter of the next).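

With hydrogen in place of ethyl on a saturated chain carbon, nine bonds along the chain from an amine nitrogen, this assay shows a 1.8-fold higher number from compound 2 to compound 3 (0.27 log units; within the scatter) and so does not separate these two chain lengths. Taken over the whole span, hydrogen in place of propyl gives a 6.9-fold higher number from compound 1 to compound 3 (0.84 log units; beyond the scatter) and stays clearly beyond the scatter, so among these three compounds chain length registers only when compound 1 is set against a shorter chain, not between compound 2 and compound 3. No evidence is available that would explain this dependence on chain length.

The compounds shown leave open whether a longer chain than that of compound 1 would lower the number further or whether the trend would turn. They also leave open how a chain ending in a hydroxyl group or a phenyl ring would behave at this position.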